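Acetylpiperidine in place of the pyrazole amide

The source may hold more compounds than are shown below. What is called first, only, known or untested is meant among the compounds shown, and "the series" means these compounds.

Compound 1 `CN(C)C(=O)c1cc(-c2cnc(NCc3c(F)ccc4c3CCO4)c3cn[nH]c(=O)c23)n(C)n1` carries a 3-(dimethylcarbamoyl)-1-methyl-1H-pyrazol-5-yl group on the shared core. In a physicochemical assay for lipophilicity, using the shake flask method, in phosphate buffer, measured as octanol-water partition, with a stated time of 30 min, at pH 7.4 (on this read-out lower numbers stand for lower lipophilicity and higher numbers for higher lipophilicity), compound 1 gives 2.1. Compound 3 `O=C(Nc1cnc(NCc2c(F)ccc3c2CCO3)n2cnnc12)c1cccnc1`, built on a different core, gives 2 in this assay, a number that lies within the usual scatter of the value for compound 1. Compound 2 `Fc1ccc2c(c1CNc1ncc(Oc3ccccc3)c3nncn13)CCO2` gives 3.5 in this assay and stands well above both compound 1 and compound 3. Among the compounds with values here, the only measured step with a single point of difference is a number 1.50 log units lower from compound 2 to compound 3 (beyond the scatter); it concerns another position and another core, so it does not bear directly on the exchange considered here. Compound 4 `CC(=O)N1CCC(c2cnc(NCc3c(F)ccc4c3CCO4)c3cn[nH]c(=O)c23)CC1` differs from compound 1 by 1-acetylpiperidin-4-yl in place of 3-(dimethylcarbamoyl)-1-methyl-1H-pyrazol-5-yl on an aromatic carbon. Within the data shown here, no measured step touches this exchange, and the value of compound 1 in this assay is the only anchor; both the leaving and the entering group carry no net charge, and no step beyond the scatter is expected in either direction. Compound 4 is expected to give about 2 in this assay, with a range of 1.5 to 2.6, which means an estimated step of a number 0.10 log units lower from compound 1 to compound 4 (within the scatter).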

Compound 4, distribution coefficient: 2.9
The estimate for compound 4 lay 0.90 log units below the measured number; measured number outside the range, above it.
By their numbers in this assay, from the lowest: compounds 3 and 1 (each within the scatter of the next); then compound 4; then compound 2.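

In this assay, this place on the aromatic carbon of the shared core is sensitive to the exchange of groups: the change gives a number 0.80 log units higher from compound 1 to compound 4 (beyond the scatter), the first step read at this place, since the earlier step concerned another place on another core. The exchange alters several things at once: a five-membered aromatic ring with 2 hetero atoms gives way to a six-membered non-aromatic ring with 1 hetero atom, 11 heavy atoms to 9, and 3 hydrogen-bond acceptors to 1 hydrogen-bond acceptor, while neither group carries a net charge and each has 1 double bond outside aromatic rings. Nothing available on the series explains the step, and this single pair cannot assign it to any one of these differences.

Still open, from the compounds shown here alone, is which part of the exchange carries the step, the ring or the amide-bearing substituent on it. A piperidin-4-yl group with a free ring amine, a 1-methyl-1H-pyrazol-5-yl group without the dimethylcarbamoyl part, or a carboxylic acid on either ring would each separate these contributions on the same core.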